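Dimethylamino in place of phenyl: what to expect

The compounds below may be only part of what the source reports. "The series", "measured", "known", "first", "only" and "open" are said of these compounds alone.

Values from a toxicity assay on MDCK cells (Canis lupus familiaris) for cytotoxicity, read by CCK-8 assay, with a stated time of 48 h (on this read-out lower numbers stand for higher toxicity in this test and higher numbers for lower toxicity in this test), for three compounds
- compound 1 `CCc1ccc(C(=O)NNc2c(Br)cccc2Br)cc1` gives > 100000 nM as a limit of the assay
- compound 2 `COC(=O)c1ccc(C(=O)NNc2c(Br)cccc2Br)cc1` gives 87600 nM
- compound 3 `O=C(NNc1c(Br)cccc1Br)c1ccc(-c2ccccc2)cc1` gives 84100 nM

In this assay compound 3 stands at 84100 nM and lies within the scatter of compound 2 at 87600 nM on this read-out. Compound 1 gives only a limit, > 100000 nM on this read-out.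

The next compound is compound 4 `CN(C)c1ccc(C(=O)NNc2c(Br)cccc2Br)cc1`, which carries dimethylamino in place of phenyl on an aromatic carbon, para to a large group. The counted difference is dimethylamino in place of phenyl on an aromatic carbon in full.

Three measured steps exchange groups at that same place. They are an at least 1.1-fold lower number from compound 1 to compound 2 (0.05 log units; that floor lies within the scatter) and an at least 1.1-fold lower number from compound 1 to compound 3 (0.07 log units; that floor lies within the scatter) and finally a 1.0-fold lower number from compound 2 to compound 3 (0.02 log units; within the scatter) in this series. None of them goes beyond the scatter, although the two starting from compound 1 give only floors. Within the data shown here, no measured compound here carries dimethylamino, so the expectation rests on these steps alone. A result given only as a limit is also possible for compound 4. The expected step is a 1.1-fold higher number from compound 3 to compound 4 (0.03 log units; within the scatter) and so none beyond the scatter. Compound 4 is estimated at 90000 nM, with an expected range of 50000 nM to 160000 nM.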

Compound 4, half-maximal cytotoxic concentration: > 100000 nM
Compound 4 ended at the assay's limit (the forecaster's own chance of this, stated with the estimate: 40%); middle value at least 1.1-fold (0.04 log units) from the limit.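

At this place on the shared core, the phenyl ring can give way to dimethylamino, a smaller group with a nitrogen and a hydrogen-bond acceptor, without any fall in the number in this assay: the step is an at least 1.1-fold higher number from compound 3 to compound 4 (0.07 log units; that floor lies within the scatter). Exchanging methoxycarbonyl for dimethylamino gives an at least 1.1-fold higher number from compound 2 to compound 4 (0.05 log units; that floor lies within the scatter), so neither step shows a change beyond the scatter, and both give only a floor, not a true size. Compound 4 now shares the assay's limit with compound 1, and the step between these two cannot be read: the limit of > 100000 nM in this assay, at which 2 of the 4 values shown sit.

Across the four compounds, the groups tried at this place leave the values close together or at the limit, so it remains open whether any group here can bring the number clearly down. A carboxylic acid, a primary amine or a longer alkyl chain such as butyl would test this, although only a value clearly below the limit would give a step of readable size.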